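Removing the amino group from compound 2: expected cytotoxicity

The source may report more compounds than this note shows. Statements on the series, on what has been measured and on what is new or still open speak of the compounds shown alone.

compound 1 `CC(=O)Nc1ccc2c(c1)/C(=C(/Nc1ccc(CN3CCCCC3)cc1)c1ccccc1)C(=O)N2` — > 6 uM
compound 2 `Nc1ccc2c(c1)/C(=C(/Nc1ccc(CN3CCCCC3)cc1)c1ccccc1)C(=O)N2` — > 6 uM

In an ADME assay on HepG2 cells (Homo sapiens) for cytotoxicity, read by MTT assay, with a stated time of 48 h (on this read-out lower numbers stand for higher toxicity in this test and higher numbers for lower toxicity in this test), compound 2 gives only a limit, > 6 uM. Compound 1 likewise gives only a limit, > 6 uM. The step that the two limits leave unreadable from compound 1 to compound 2 is therefore not readable. Compound 3 `O=C1Nc2ccccc2/C1=C(/Nc1ccc(CN2CCCCC2)cc1)c1ccccc1` differs from compound 2 by hydrogen in place of amino on an aromatic carbon. Among the measured compounds shown here, no measured step bears directly on this change; the only evidence is the limit of > 6 uM in this assay, at which 2 of the 2 values shown sit. Compound 3 is expected to remain at that limit, so the estimated step that the limit leaves unreadable from compound 2 to compound 3 is expected to show no readable size. Compound 3 is estimated at 10 uM, between 4 uM and 40 uM.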

Compound 3, half-maximal toxic concentration: > 6 uM
Compound 3: a limit, no number; the forecaster's own chance of this, stated with the estimate: 70%; the middle value does not contradict the limit.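

In this assay, among the compounds shown here, compound 3 gives only a limit, > 6 uM, and no step among compound 1, compound 2 and compound 3 can be read. The compounds shown leave open whether amino or acetamido changes the toxic concentration at all.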